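This account rests on a few compounds, and the source may have more. Where it says the series, first, only, none or still open, it means among the compounds named here.

In a functional assay on microsomes from liver (Rattus norvegicus, strain Wistar) for inhibition, with a stated time of 15 min (a higher number here means a weaker inhibitor, a lower number a stronger inhibitor), compound 1 `COc1cc(C2CC(c3cc4ccccc4o3)=NN2C(=O)Nc2cccc(O)c2)ccc1O` gives 24000000 nM, compound 2 `COc1cc(C2CC(c3cc4ccccc4o3)=NN2C(=O)Nc2ccccc2)ccc1O` gives 116000000 nM and compound 3 `COc1cc(C2CC(c3cc4ccccc4o3)=NN2C(=O)Nc2ccc(Cl)cc2)ccc1O` gives 121000000 nM. That last value sits at the high end of the three numbers, shared within the scatter: a 1.0-fold higher number from compound 2 to compound 3 (0.02 log units; within the scatter), while a 5.0-fold higher number from compound 1 to compound 3 (0.70 log units; beyond the scatter).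

Compound 4 `COc1cc(C2CC(c3cc4ccccc4o3)=NN2C(=O)Cl)ccc1O` has chloro in place of (4-chlorophenyl)amino on a carbonyl carbon. Among the measured compounds shown here, no measured step removes this whole group, so the evidence is indirect. For the measured compounds named here, the only steps available are changes within the group that leaves. Two are modest, a 4.8-fold higher number from compound 1 to compound 2 (0.68 log units; beyond the scatter) and the step to compound 3 given above, and one lies within the scatter, the step from compound 2 given above.

On these data alone, on these steps, no shift beyond the scatter is expected in this assay as the central case, and the direction stays open. The estimated step is a 1.2-fold lower number from compound 3 to compound 4 (0.08 log units; within the scatter). With so little direct evidence the range is kept wide. Compound 4 is estimated at 100000000 nM, with an expected range of 25000000 nM to 400000000 nM.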

Compound 4, half-maximal inhibitory concentration: 147000000 nM
Beside the measured number, compound 4's estimate is 1.5-fold (0.17 log units) below it; the measured number falls inside the stated range.
By their numbers in this assay, from the lowest: compound 1; then compounds 2, 3 and 4 (each within the scatter of the next).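

In this assay, the entire (4-chlorophenyl)amino group on the carbonyl carbon gives way to chloro with no shift beyond the scatter (a 1.2-fold higher number from compound 3 to compound 4 (0.08 log units; within the scatter)), and the same holds for the loss of anilino (a 1.3-fold higher number from compound 2 to compound 4 (0.10 log units; within the scatter)). Among compounds 2, 3 and 4, the aromatic ring and the amide hydrogen of the leaving group therefore bring no measurable difference at this position. Compound 1 goes against this, since replacing its (3-hydroxyphenyl)amino group with chloro does shift the number (a 6.1-fold higher number from compound 1 to compound 4 (0.79 log units; beyond the scatter)), and nothing available explains either result.

On these data alone, it remains open whether a hydroxy group is the only substituent on that aromatic ring to separate from the rest. As far as these compounds go, a simple amine, a carboxylic acid or a longer alkyl chain on the carbonyl carbon also remains untested in these compounds.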